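Second methoxy on the pendant aryl of the series

A few compounds are considered here, and "the series" means these few. Any claim that something is new, unique, unknown or untested is made for them only; others in the source may bear on it.

The three measured compounds share one core and differ only on the pendant phenyl ring. Compound 1 `COc1cc2c(Oc3ccc(NC(=O)c4cc(-c5ccccc5)ccn4)cc3F)ccnc2cc1OCCCN1CCCC1` gives 210 nM in a functional assay on MKN-45 cells (Homo sapiens) for cytotoxicity, read by MTT assay, with a stated time of 72 h; on this read-out lower numbers stand for stronger inhibition and higher numbers for weaker inhibition. Compound 2 `COc1cc2c(Oc3ccc(NC(=O)c4cc(-c5ccc(F)cc5)ccn4)cc3F)ccnc2cc1OCCCN1CCCC1` gives 350 nM, and compound 3 `COc1ccc(-c2ccnc(C(=O)Nc3ccc(Oc4ccnc5cc(OCCCN6CCCC6)c(OC)cc45)c(F)c3)c2)cc1` gives 150 nM. The steps are small: a 1.7-fold higher number from compound 1 to compound 2 (0.22 log units; within the scatter), a 1.4-fold lower number from compound 1 to compound 3 (0.15 log units; within the scatter), and a 2.3-fold lower number from compound 2 to compound 3 (0.37 log units; beyond the scatter). Compound 3 thus stands at the low end of the three numbers, separated from compound 2 beyond the scatter but from compound 1 only within it.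

Compound 4 `COc1ccc(-c2ccnc(C(=O)Nc3ccc(Oc4ccnc5cc(OCCCN6CCCC6)c(OC)cc45)c(F)c3)c2)c(OC)c1` is not yet measured. It differs from compound 3 by methoxy in place of hydrogen on an aromatic carbon.

The step that bears most directly on this is the earlier addition of a methoxy group, a 1.4-fold lower number from compound 1 to compound 3 (0.15 log units; within the scatter), which stayed within the scatter; the fluoro addition, a 1.7-fold higher number from compound 1 to compound 2 (0.22 log units; within the scatter), also stayed within the scatter. On that basis a second methoxy on the same ring is expected to move the number little, with no step beyond the scatter in either direction, a 1.2-fold higher number from compound 3 to compound 4 (0.08 log units; within the scatter). Compound 4 is therefore estimated at 180 nM, with a range from 80 nM to 400 nM.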

Compound 4, half-maximal inhibitory concentration: 740 nM
The estimate for compound 4 lay 4.1-fold (0.61 log units) below the measured number; the whole stated range lies below it.
By their numbers in this assay, from the lowest: compounds 3, 1 and 2 (each within the scatter of the next, the first and the last beyond it); then compound 4.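

In this assay, among the compounds shown here, methoxy in place of hydrogen does not read the same at every place on the pendant ring: where it gave a step within the scatter in forming the 4-methoxyphenyl of compound 3, its entry ortho to a large group gives a 4.9-fold higher number from compound 3 to compound 4 (0.69 log units; beyond the scatter) and is the largest step so far. For the compounds shown here, the 2,4-dimethoxyphenyl also stands beyond the scatter against the other two rings, with a 3.5-fold higher number from compound 1 to compound 4 (0.55 log units; beyond the scatter) against the phenyl and a 2.1-fold higher number from compound 2 to compound 4 (0.33 log units; beyond the scatter) against the 4-fluorophenyl, so compound 4 holds the highest number of the four and the pendant ring is less tolerant of change than the earlier compounds suggested. Nothing available on these compounds gives a reason for this rise.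

Open, as far as these compounds go, is whether a single methoxy ortho to a large group, without the 4-methoxy, would give the same rise, or whether the rise needs both methoxy groups on the ring. Also open, from the compounds shown here alone, is how a smaller fluoro, a hydroxy or an amine such as dimethylamino would read at that same place.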